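The compounds below may be only part of what the source reports. "The series", "measured", "known", "first", "only" and "open" are said of these compounds alone.

Measured compounds:
compound 2 `CCNC(=O)c1cc(Oc2ccc(NC(=O)c3cc4cccnc4n(-c4ccc(F)cc4)c3=O)cc2)ccn1` — 220 nM
compound 1 `CNC(=O)c1cc(Oc2ccc(NC(=O)c3cc4cccnc4n(-c4ccc(OC)cc4)c3=O)cc2)ccn1` — "not determined" (no result reported)

For the measured compounds named here, compound 2 is the only one of the pair with a number in a functional assay on NCI-H460 cells (Homo sapiens) for antiproliferative activity, read by MTT assay, with a stated time of 72 h; on this read-out higher numbers stand for weaker inhibition and lower numbers for stronger inhibition; for compound 1 the outcome in this assay is recorded as "not determined" (no result reported), so no comparison between them can be drawn. On the numbers shown, compound 2 therefore stands alone.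

The step under consideration leads to compound 3 `CCNC(=O)c1cc(Oc2ccc(NC(=O)c3cc4cccnc4n(-c4ccc(OC)cc4)c3=O)cc2)ccn1`. The change is methoxy in place of fluoro on an aromatic carbon, the same difference read one bond further out being 4-fluorophenyl to 4-methoxyphenyl. No measured step of this kind exists among these compounds, so no direction can be read from them. Compound 3 is expected to sit close to compound 2, with the step of a 1.2-fold higher number from compound 2 to compound 3 (0.07 log units; within the scatter) estimated to lie within the usual scatter. The estimate for compound 3 in this assay is 260 nM, with a range from 90 nM to 750 nM.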

Compound 3, half-maximal inhibitory concentration: 1720 nM
Beside the measured number, compound 3's estimate is 6.6-fold (0.82 log units) below it; the measured number lies above the stated range.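

In this assay, for the compounds shown here, the first readable step at this position, 4-fluorophenyl to 4-methoxyphenyl, gives a 7.8-fold higher number from compound 2 to compound 3 (0.89 log units; beyond the scatter). The aromatic carbon para to a large group is therefore not indifferent to what it carries, and here methoxy in place of fluoro goes with weaker inhibition of cell growth. No measurement on these compounds accounts for this shift. 

This single pair leaves open how other groups at this place would behave, such as chloro, hydroxy or a dimethylamino group, and whether the shift follows the oxygen or the added carbon. With compound 1 recorded as "not determined" (no result reported), the methyl amide cannot be compared with the ethyl amide of compound 3, so the effect of that chain remains unread.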